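The source may hold more compounds than are shown below. What is called first, only, known or untested is meant among the compounds shown, and "the series" means these compounds.

Compound 3 `CCOC(=O)c1oc2ccc(NS(=O)(=O)c3ccccc3Cl)cc2c1C` belongs to a small set of sulfonamides that share one core and differ only in the aryl group on the sulfonyl sulfur. In a functional assay on MDA-MB-231 cells (Homo sapiens) for antiproliferative activity, read by MTT assay, with a stated time of 72 h (a higher number here means a weaker inhibitor, a lower number a stronger inhibitor), compound 3 gives no number but only a limit, > 200000 nM. That limit is the limit of > 200000 nM in this assay, at which 1 of the 3 values shown sits. Compound 1 `CCOC(=O)c1oc2ccc(NS(=O)(=O)c3ccccc3C)cc2c1C`, carrying a 2-methylphenyl on the sulfonyl sulfur, gives in this assay 89200 nM. Compound 2 `CCOC(=O)c1oc2ccc(NS(=O)(=O)c3ccc(Cl)cc3)cc2c1C`, carrying a 4-chlorophenyl, gives in this assay 53900 nM. Compound 4 `CCOC(=O)c1oc2ccc(NS(=O)(=O)c3ccc(Br)cc3)cc2c1C` has not yet been measured; it differs from compound 3 in that (4-bromophenyl in place of 2-chlorophenyl on a sulfonyl sulfur). For the measured compounds named here, two measured steps bear on this change. The step of an at least 3.7-fold higher number from compound 2 to compound 3 (0.56 log units; beyond the scatter) shows the 2-chlorophenyl sitting well above the 4-chlorophenyl, and an at least 2.2-fold higher number from compound 1 to compound 3 (0.35 log units; beyond the scatter) points the same way, while a 1.7-fold lower number from compound 1 to compound 2 (0.22 log units; within the scatter) shows the 4-chlorophenyl and the 2-methylphenyl close together. Compound 4, with a halogen in the same position as compound 2, is therefore expected to fall back toward compound 2 rather than stay at the limit of compound 3. In this assay compound 4 is estimated at 55000 nM, with a range from 20000 nM to 160000 nM. That would be an expected step of an at least 3.6-fold lower number from compound 3 to compound 4 (0.56 log units; beyond the scatter).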

Compound 4, half-maximal inhibitory concentration: 31100 nM
Beside the measured number, compound 4's estimate is 1.8-fold (0.25 log units) above it, within the range that was stated.
By their numbers in this assay, from the lowest: compounds 4, 2 and 1 (each within the scatter of the next, the first and the last beyond it). At a limit, above all of these: compound 3.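

Going from the 2-chlorophenyl to the 4-bromophenyl on the sulfonyl sulfur gives an at least 6.4-fold lower number from compound 3 to compound 4 (0.80 log units; beyond the scatter) in this assay and so confirms, with a second halogen, that compound 3 stands apart from the compounds carrying a 4-substituted ring. Bromo in place of chloro gives a 1.7-fold lower number from compound 2 to compound 4 (0.24 log units; within the scatter) and so does not separate the two 4-halophenyl compounds. Compound 4 does separate from the 2-methylphenyl compound, with a 2.9-fold lower number from compound 1 to compound 4 (0.46 log units; beyond the scatter) as the step, whereas compound 2 stayed within the scatter of compound 1.

From the compounds shown here alone, how far compound 3 truly lies from the others stays open, as compound 3 has only a limit: the limit of > 200000 nM in this assay, at which 1 of the 4 values shown sits. Also open, going by these compounds, is how a 2-bromophenyl, a 4-methylphenyl or a 4-aminophenyl on the sulfonyl sulfur would read in this assay against these compounds.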